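The source may hold more compounds than are shown below. What is called first, only, known or untested is meant among the compounds shown, and "the series" means these compounds.

Measured compounds and their values:
- compound 1 `COc1ccc([N+](=O)[O-])cc1CSc1nc2cc(NC(=O)NC(C)(C)C)ccc2n1C1CC1`: in an assay on isolated protein for inhibition of Gonadotropin-releasing hormone receptor (Homo sapiens) (a lower number here means a stronger inhibitor, a higher number a weaker inhibitor), compound 1 gives 79 nM
- compound 2 `CCn1c(SCc2cc([N+](=O)[O-])ccc2OC)nc2cc(NC(=O)NC(C)(C)C)ccc21`: compound 2 gives 42 nM
- compound 3 `CCCCn1c(SCc2cc([N+](=O)[O-])ccc2OC)nc2cc(NC(=O)NC(C)(C)C)ccc21`: compound 3 gives 23 nM

Compound 3 stands at the lowest of the three numbers, with a 3.4-fold lower number from compound 1 to compound 3 (0.54 log units; beyond the scatter) and a 1.8-fold lower number from compound 2 to compound 3 (0.26 log units; within the scatter). Compound 4 `COCCn1c(SCc2cc([N+](=O)[O-])ccc2OC)nc2cc(NC(=O)NC(C)(C)C)ccc21` differs from it by methoxy in place of ethyl on a saturated chain carbon, two bonds along the chain from an aromatic nitrogen. The step that bears on this position is a 1.8-fold lower number from compound 2 to compound 3 (0.26 log units; within the scatter), which shows that adding to this carbon changes little; the step of a 1.9-fold lower number from compound 1 to compound 2 (0.27 log units; within the scatter) is likewise small. Within the data shown here, no measured step places an oxygen in this chain, so the data give no direct guide for the methoxy. A step within the scatter in this assay is therefore expected, with a slight lean toward a higher number. Compound 4 is estimated at 35 nM, range 15 nM to 90 nM, which would mean a step of a 1.5-fold higher number from compound 3 to compound 4 (0.18 log units; within the scatter).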

Compound 4, half-maximal inhibitory concentration: 57 nM
Compound 4: middle estimate off by 1.6-fold (0.21 log units), on the low side, and the stated range covers the measured number.
By their numbers in this assay, from the lowest: compounds 3, 2, 4 and 1 (each within the scatter of the next, the first and the last beyond it).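

In this assay, the swap of ethyl for methoxy on this chain carbon keeps the heavy-atom count yet gives a step beyond the scatter (a 2.5-fold higher number from compound 3 to compound 4 (0.39 log units; beyond the scatter)), which the earlier step at this carbon did not. The 2-methoxyethyl chain of compound 4 stays within the scatter of both the ethyl of compound 2 (a 1.4-fold higher number from compound 2 to compound 4 (0.13 log units; within the scatter)) and the cyclopropyl of compound 1 (a 1.4-fold lower number from compound 1 to compound 4 (0.14 log units; within the scatter)). No evidence is available on what lies behind the step from butyl to 2-methoxyethyl.

As far as these compounds go, whether a 2-hydroxyethyl or 2-aminoethyl chain on the aromatic nitrogen would fall nearer compound 3 or compound 4 remains open.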